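The compounds below may be only part of what the source reports. "The series", "measured", "known", "first", "only" and "open" are said of these compounds alone.

Measured in a functional assay on K562 cells (Homo sapiens), read by MTT assay, with a stated time of 72 h; on this read-out higher numbers stand for weaker inhibition and lower numbers for stronger inhibition:
Compound 1 `CSc1ncnc2c1c(-c1ccoc1)cn2[C@@H]1O[C@H](CO)[C@@H](O)[C@H]1O`: 3250 nM
Compound 2 `COc1nc(N)nc2c1c(-c1ccoc1)cn2[C@@H]1O[C@H](CO)[C@@H](O)[C@H]1O`: > 20000 nM

Of these two compounds, only compound 1 has a numeric reading. Compound 2 reads > 20000 nM, which is a limit of the assay and not a number, so its true position is not known.

Compound 3 `COc1nc(N)nc2c1c(-c1cc3ccccc3o1)cn2[C@@H]1O[C@H](CO)[C@@H](O)[C@H]1O` keeps the core of compound 2 and carries 1-benzofuran-2-yl in place of furan-3-yl on an aromatic carbon. Among the measured compounds shown here, no measured pair shows what this change does in this assay. No step beyond the scatter is expected, in either direction. This expectation rests on compound 2, with its limit of > 20000 nM. The estimated step is an at least 1.1-fold lower number from compound 2 to compound 3 (0.04 log units; that floor lies within the scatter). A reading at the same limit would be no surprise. For compound 3 the estimated value is 18000 nM, with an expected range from 6000 nM to 30000 nM.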

Compound 3, half-maximal inhibitory concentration: 15500 nM
Estimate against measurement, compound 3: 1.2-fold (0.06 log units) above; measured number inside the range.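

In this assay compound 3 reads 15500 nM and so gives this series a numeric reading with 1-benzofuran-2-yl on this aromatic carbon, which compound 2 with furan-3-yl did not provide. Exchanging furan-3-yl for 1-benzofuran-2-yl, which brings in a six-membered aromatic ring of carbon only, gives an at least 1.2-fold lower number from compound 2 to compound 3 (0.11 log units; that floor lies within the scatter) on this core. Only a floor for this step can be read, and whether the true step goes beyond the scatter stays unsettled, because compound 2 stands at a limit and not at a number: the limit of > 20000 nM in this assay, at which 1 of the 3 values shown sits.

The compounds shown leave open how a plain phenyl ring, an amine or a carboxylic acid on this aromatic carbon would read on the same core. They also leave open whether 1-benzofuran-2-yl would behave alike on the core of compound 1.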